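Cytotoxicity notes: 4-cyanophenyl to 4-nitrophenyl

The source may report more compounds than this note shows. Statements on the series, on what has been measured and on what is new or still open speak of the compounds shown alone.

Within the data shown here, in an ADME assay on BJ cells (Homo sapiens) for cytotoxicity, with a stated time of 72 h (on this read-out higher numbers stand for an effect only at larger amounts of compound and lower numbers for an effect already at smaller amounts), compound 1 `Cc1ccc(-c2nc3c(c(C)nn3-c3ccccc3)c(-c3ccccc3O)c2C#N)cc1` gives 22200 nM as the only number. Compound 2 `Cc1nn(-c2ccccc2)c2nc(-c3ccc(F)cc3)c(C#N)c(-c3ccccc3O)c12` gives > 20000 nM as a limit. Compound 3 `Cc1nn(-c2ccccc2)c2nc(-c3ccc(C#N)cc3)c(C#N)c(-c3ccccc3O)c12` gives > 20000 nM as a limit too, so it has no number. This is the limit of > 20000 nM in this assay, at which 2 of the 3 values shown sit, and it fixes where compound 3 stands. Compound 4 `Cc1nn(-c2ccccc2)c2nc(-c3ccc([N+](=O)[O-])cc3)c(C#N)c(-c3ccccc3O)c12` differs from compound 3 by nitro in place of cyano on an aromatic carbon, para to a large group (nitro in place of cyano on an aromatic carbon). Among the measured compounds shown here, three measured steps bear on this change: a step that the limit leaves unreadable from compound 1 to compound 2 and a step that the limit leaves unreadable from compound 1 to compound 3 and a step that the two limits leave unreadable from compound 2 to compound 3 give no size. An expected step that the limit leaves unreadable from compound 3 to compound 4 therefore carries no direction beyond the scatter. The estimated value for compound 4 is 21000 nM within a range of 10000 nM to 40000 nM and another limit reading is likely.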

Compound 4, half-maximal effective concentration: > 20000 nM
Compound 4: a limit, no number; the forecaster's own chance of this, stated with the estimate: 65%; the middle value does not contradict the limit.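

In this assay compound 4 gives > 20000 nM, a limit and not a number, so no step from compound 1, compound 2 or compound 3 to compound 4 can be read: the limit of > 20000 nM in this assay, at which 3 of the 4 values shown sit.

The compounds shown leave open whether methyl, fluoro, cyano and nitro differ at all in this read-out.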